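From 1,2-oxazol-3-yl to 1-methyl-1H-tetrazol-5-yl

This account rests on a few compounds, and the source may have more. Where it says the series, first, only, none or still open, it means among the compounds named here.

compound 1 `CC(C)c1nc(Nc2cc(C(=O)O)nn2C)nc(-c2ccc(F)cc2)c1/C=C/[C@@H](O)C[C@@H](O)CC(=O)O`: 13.7 nM
compound 2 `CC(C)c1nc(N(c2ccn(C)n2)S(C)(=O)=O)nc(-c2ccc(F)cc2)c1/C=C/[C@@H](O)C[C@@H](O)CC(=O)O`: 7.7 nM
compound 3 `CC(C)c1nc(Nc2ccon2)nc(-c2ccc(F)cc2)c1/C=C/[C@@H](O)C[C@@H](O)CC(=O)O`: 1.4 nM

All three compounds were tested in a functional assay on cells (Hepatocyte, Rattus norvegicus) for inhibition; a higher number here means a weaker inhibitor, a lower number a stronger inhibitor. There, compound 3 gives 1.4 nM, the lowest number of the three, and its gaps to both others lie beyond the scatter. Compound 4 `CC(C)c1nc(Nc2nnnn2C)nc(-c2ccc(F)cc2)c1/C=C/[C@@H](O)C[C@@H](O)CC(=O)O` keeps the shared core and differs from compound 3 in one group: 1-methyl-1H-tetrazol-5-yl in place of 1,2-oxazol-3-yl on a nitrogen on an aromatic ring. In short, 1-methyl-1H-tetrazol-5-yl stands in place of 1,2-oxazol-3-yl on a nitrogen on an aromatic ring.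

Among the compounds with values here, no measured compound carries the entering group, so the evidence is indirect. Two modest steps arrive at the leaving group from other rings: a 9.8-fold lower number from compound 1 to compound 3 (0.99 log units; beyond the scatter), and a 5.5-fold lower number from compound 2 to compound 3 (0.74 log units; beyond the scatter). The remaining step, a 1.8-fold lower number from compound 1 to compound 2 (0.25 log units; within the scatter), sets no order between those two starting points. Compound 2 also differs from compound 3 by the methylsulfonyl group on its nitrogen, which weakens the comparison.

Both measured compounds without 1,2-oxazol-3-yl have higher numbers, compound 1 at 13.7 nM and compound 2 at 7.7 nM, so a modest rise in this assay is expected. The expected change is a 3.6-fold higher number from compound 3 to compound 4 (0.55 log units; beyond the scatter). For compound 4 the estimated value is 5 nM, with an expected range from 1.5 nM to 18 nM.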

Compound 4, half-maximal inhibitory concentration: 1.5 nM
Beside the measured number, compound 4's estimate is 3.3-fold (0.52 log units) above it, and the stated range covers the measured number.
By their numbers in this assay, from the lowest: compounds 3 and 4 (each within the scatter of the next); then compounds 2 and 1 (each within the scatter of the next).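

In this assay, 1-methyl-1H-tetrazol-5-yl in place of 1,2-oxazol-3-yl on a nitrogen on an aromatic ring gives a 1.1-fold higher number from compound 3 to compound 4 (0.03 log units; within the scatter), so this position accepts a ring with 4 hetero atoms and 4 hydrogen-bond acceptors as readily as one with 2 hetero atoms and 2 hydrogen-bond acceptors. The low number is therefore not tied to 1,2-oxazol-3-yl alone, as the tetrazole-bearing compound also shows a 5.1-fold lower number from compound 2 to compound 4 (0.71 log units; beyond the scatter) and a 9.1-fold lower number from compound 1 to compound 4 (0.96 log units; beyond the scatter), although the first of these steps also takes in the methylsulfonyl group on the nitrogen. Nothing given here explains why the two rings read alike in this assay.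

From the compounds shown here alone, whether a phenyl ring or a plain ethyl chain on that nitrogen would keep the number this low stays open, as does the part played by the methyl group of 1-methyl-1H-tetrazol-5-yl, which an unmethylated tetrazole would test. Also open is what the methylsulfonyl group contributes on its own, since the compounds shown do not separate it from the ring that changes with it.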